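Swapping fluoro for chloro on a sulfonamide aryl ring

The source may hold more compounds than are shown below. What is called first, only, known or untested is meant among the compounds shown, and "the series" means these compounds.

Measured so far:
Compound 1 `C=Cc1ccc(S(=O)(=O)Nc2ccc3oc(-c4ccccc4)nc3c2)cc1`: > 63000 nM
Compound 2 `O=S(=O)(Nc1ccc(-c2nc3ccccc3o2)cc1)c1cccc(Cl)c1`: > 63000 nM
Compound 3 `O=S(=O)(Nc1ccc2oc(-c3ccccc3)nc2c1)c1ccc(F)c(C(F)(F)F)c1`: > 63000 nM

All three measured compounds share a sulfonamide linking two aromatic parts, and all three were tested in an assay on isolated protein for inhibition of malate dehydrogenase, mitochondrial (Sus scrofa), with stated times of 45 min and 30 min; a higher number here means a weaker inhibitor, a lower number a stronger inhibitor. For compound 1 the result is only a limit of the assay, > 63000 nM, not a number. For compound 2 the result is likewise a limit, > 63000 nM. For compound 3 the result is again a limit, > 63000 nM. So compound 3 stands nowhere distinguishable among the values shown: every result sits at the same limit, as summed up in the limit of > 63000 nM in this assay, at which 3 of the 3 values shown sit, and none of the three compounds can be ranked against another.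

The next compound, compound 4 `O=S(=O)(Nc1ccc2oc(-c3ccccc3)nc2c1)c1ccc(Cl)c(C(F)(F)F)c1`, differs from compound 3 in one place: chloro in place of fluoro on an aromatic carbon. Among the compounds with values here, no measured pair shows what such a swap does here, and the three values give no foothold for a step in either direction. A small step or none beyond the scatter is expected, most likely leaving compound 4 at the limit as well.

Compound 4 is therefore expected to give about 80000 nM in this assay, within 30000 nM to 250000 nM, corresponding to an estimated step that the limit leaves unreadable from compound 3 to compound 4.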

Compound 4, half-maximal inhibitory concentration: > 63000 nM
Compound 4 ended at the assay's limit; the forecaster's own chance of this, stated with the estimate: 85%; the middle value does not contradict the limit.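

Compound 3 and compound 4 both end at a limit of this assay rather than at a number, so no step can be read for chloro in place of fluoro. The compounds shown leave open which change in structure, if any, would give a measurable value, since all of them share one result: the limit of > 63000 nM in this assay, at which 4 of the 4 values shown sit.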